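Thiophene for Furan on an Amide Carbonyl

The compounds below may be only part of what the source reports. "The series", "measured", "known", "first", "only" and "open" are said of these compounds alone.

Compound 1, `CCCCC(=O)Nc1ccc(N2CCN(c3ccc(OC[C@@H]4CO[C@@](Cn5cncn5)(c5ccc(Cl)cc5Cl)O4)cc3)CC2)cc1`: in a toxicity assay on L02 cells (Homo sapiens) for inhibition, read by MTT assay, with a stated time of 48 h (on this read-out higher numbers stand for weaker inhibition and lower numbers for stronger inhibition), compound 1 gives > 50000 nM, which is a limit of the assay.
Compound 2, `O=C(CC1CCOCC1)Nc1ccc(N2CCN(c3ccc(OC[C@@H]4CO[C@@](Cn5cncn5)(c5ccc(Cl)cc5Cl)O4)cc3)CC2)cc1`: in this assay compound 2 gives > 50000 nM, again a limit.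
Compound 3, `O=C(Nc1ccc(N2CCN(c3ccc(OC[C@@H]4CO[C@@](Cn5cncn5)(c5ccc(Cl)cc5Cl)O4)cc3)CC2)cc1)c1ccco1`: in this assay compound 3 gives > 50000 nM, again a limit.

Compound 3 thus stands where every measured compound stands, namely at the limit of > 50000 nM in this assay, at which 3 of the 3 values shown sit. Every value is a limit. Going by the values given here, none of the measured steps can be sized: a step that the two limits leave unreadable from compound 1 to compound 2, a step that the two limits leave unreadable from compound 1 to compound 3 and a step that the two limits leave unreadable from compound 2 to compound 3 all remain unreadable. Compound 4, `O=C(Nc1ccc(N2CCN(c3ccc(OC[C@@H]4CO[C@@](Cn5cncn5)(c5ccc(Cl)cc5Cl)O4)cc3)CC2)cc1)c1cccs1`, differs from compound 3 in one place: thiophen-2-yl in place of furan-2-yl on a carbonyl carbon. Among the compounds with values here, all three measured steps exchange the group on the carbonyl carbon of the amide, so they are the only steps that bear on this change, and each of them is a step between two limits. Within the data shown here, no measured step reports a number, so no direction can be read from them. Compound 4 is therefore expected to sit at the limit as well, an expected step that the limit leaves unreadable from compound 3 to compound 4. The estimate for compound 4 in this assay is 80000 nM, with a range from 40000 nM to 200000 nM.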

Compound 4, half-maximal inhibitory concentration: > 50000 nM
Compound 4: only a limit was reported; the forecaster's own chance of this, stated with the estimate: 90%; the middle value is on the limit's open side.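

In this assay compound 4 gives > 50000 nM, which is a limit. Its steps from compound 1, compound 2 and compound 3 cannot be read, and all four compounds share one position: the limit of > 50000 nM in this assay, at which 4 of the 4 values shown sit.

The compounds shown leave open whether any group on the carbonyl carbon changes the read-out in this assay at all.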